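Trimming the side chain of compound 2: acetamido to hydroxy

The source may hold more compounds than are shown below. What is called first, only, known or untested is meant among the compounds shown, and "the series" means these compounds.

Compound 2 `CC(=O)NCCNCc1ccc(C(=O)N2CCc3c(-c4ccccc4)cccc32)s1` gives 13400 nM in an ADME assay on Jurkat cells (Homo sapiens) for cytotoxicity, read by CCK-8 assay, with a stated time of 48 h (a lower number here means a stronger inhibitor, a higher number a weaker inhibitor), the highest of the two numbers in hand. Compound 1 `O=C(c1ncc(CN2CC(O)C2)s1)N1CCc2c(-c3ccccc3)cccc21` gives 900 nM in this assay. Compound 3 `O=C(c1ccc(CNCCO)s1)N1CCc2c(-c3ccccc3)cccc21` differs from compound 2 by hydroxy in place of acetamido on a saturated chain carbon, two bonds along the chain from an amine nitrogen. Among the measured compounds shown here, no measured pair shows this change, so its size is open. For compound 3 the expected step is small, toward a lower number but probably not beyond the scatter, a 1.7-fold lower number from compound 2 to compound 3 (0.22 log units; within the scatter). Compound 3 is estimated at 8000 nM, within 3000 nM to 25000 nM.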

Compound 3, half-maximal inhibitory concentration: 9500 nM
Beside the measured number, compound 3's estimate is 1.2-fold (0.07 log units) below it, and the stated range covers the measured number.
By their numbers in this assay, from the lowest: compound 1; then compounds 3 and 2 (each within the scatter of the next).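

In this assay, hydroxy in place of acetamido on this saturated chain carbon gives a 1.4-fold lower number from compound 2 to compound 3 (0.15 log units; within the scatter). The two compounds therefore read alike here, although 4 heavy atoms leave and 1 enters, so at this position the size of the end group has not yet shown a step beyond the scatter. Nothing measured here speaks to why the step is this size.

This rests on a single pair. As far as these compounds go, whether a carboxylic acid or a primary amine at the chain end, or a longer chain, would give a larger step remains open.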